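The compounds below may be only part of what the source reports. "The series", "measured", "known", "first", "only" and "open" are said of these compounds alone.

Working notes on the series. In a toxicity assay on MT4 cells (Homo sapiens) for cytotoxicity, read by MTT assay (a higher number here means that more compound is tolerated, a lower number that less compound is tolerated), compound 1 `Cc1cc(-c2cccc(Cl)c2)cc(C)c1Oc1cc(N)nc(Nc2ccc(C#N)cc2)n1` gives 22300 nM, compound 2 `COc1cccc(-c2cc(C)c(Oc3cc(N)nc(Nc4ccc(C#N)cc4)n3)c(C)c2)c1` gives 19300 nM and compound 3 `COc1ccc(-c2cc(C)c(Oc3cc(N)nc(Nc4ccc(C#N)cc4)n3)c(C)c2)cc1` gives 10700 nM. On these numbers, compound 3 cannot be told apart from compound 2 and stands only modestly apart from compound 1. The measured steps are a 1.8-fold lower number from compound 2 to compound 3 (0.26 log units; within the scatter), a 2.1-fold lower number from compound 1 to compound 3 (0.32 log units; beyond the scatter) and a 1.2-fold lower number from compound 1 to compound 2 (0.06 log units; within the scatter).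

Compound 4 `Cc1cc(-c2ccc(C#N)c(C#N)c2)cc(C)c1Oc1cc(N)nc(Nc2ccc(C#N)cc2)n1` follows from compound 3 by this change: 3,4-dicyanophenyl in place of 4-methoxyphenyl on an aromatic carbon. Among the measured compounds shown here, all three measured steps alter the same group, so all three bear on it, but no measured compound carries a nitrile on that group, and the transfer is uncertain. Since none of those steps is more than modest, a step of similar size is expected in this assay, probably none beyond the scatter. A slight lean to a higher number rests on compound 1, without a methoxy group, at 22300 nM. Against that lean, within the scatter of compound 1 and with a methoxy group, stands compound 2 at 19300 nM.

The estimate therefore means a 1.3-fold higher number from compound 3 to compound 4 (0.12 log units; within the scatter), an expected step of modest size. For compound 4 the estimated value is 14000 nM, with an expected range of 5000 nM to 35000 nM.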

Compound 4, half-maximal cytotoxic concentration: 17600 nM
The estimate for compound 4 lay 1.3-fold (0.10 log units) below the measured number, and the stated range covers the measured number.
By their numbers in this assay, from the lowest: compounds 3, 4, 2 and 1 (each within the scatter of the next, the first and the last beyond it).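

In this assay, the 3,4-dicyanophenyl group, the only group shown at this position that carries nitriles, stays within the scatter of all three groups it was compared with: the steps are a 1.6-fold higher number from compound 3 to compound 4 (0.22 log units; within the scatter), a 1.1-fold lower number from compound 2 to compound 4 (0.04 log units; within the scatter) and a 1.3-fold lower number from compound 1 to compound 4 (0.10 log units; within the scatter). Among the compounds shown here, the earlier compounds had only a chloro or a single methoxy group on this ring, and they gave one step beyond the scatter, a 2.1-fold lower number from compound 1 to compound 3 (0.32 log units; beyond the scatter); compound 4 lies within the scatter of both ends of that step, so the series so far tolerates two nitrile groups on this ring without a separable change in the number. Nothing measured here accounts for this result.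

The two nitrile groups enter together, so the contribution of each one to the step cannot be read from these compounds. As far as these compounds go, it also remains open whether this position stays as flat with a carboxylic acid or an aminomethyl group on the phenyl ring, or with a longer alkyl chain in place of that ring.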